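Adding 2-hydroxyethyl to the aromatic oxygen of compound 3

The compounds below may be only part of what the source reports. "The series", "measured", "known", "first", "only" and "open" are said of these compounds alone.

Three compounds on the shared core have entries so far, and only one of them carries a number. In an ADME assay on microsomes from liver (Homo sapiens) for metabolic stability, with a stated time of 30 min (a lower number here means that less of the compound is left, a higher number that more of the compound is left), compound 1 `COc1nc(Cc2cccc(Cl)c2F)cc2c(=O)c(C(=O)O)cn([C@H](CO)C(C)C)c12` has the entry "not determined" (no result reported). Compound 2 `COc1nc2c(cc1Cc1cccc(Cl)c1F)c(=O)c(C(=O)O)cn2[C@@H](C)CO` has the entry "not determined" (no result reported). Within the data shown here, compound 3 `CC(C)(C)[C@@H](CO)n1cc(C(=O)O)c(=O)c2cc(Cc3cccc(Cl)c3F)c(O)nc21` gives 87%, the only number, so it cannot yet be ranked against the others. Among the measured compounds shown here, no step between two measured compounds exists either, which leaves the coming comparison without a precedent.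

Compound 4 `CC(C)(C)[C@@H](CO)n1cc(C(=O)O)c(=O)c2cc(Cc3cccc(Cl)c3F)c(OCCO)nc21` is still to be measured. It departs from compound 3 by 2-hydroxyethyl in place of hydrogen on an oxygen on an aromatic ring, which reads as hydroxy to 2-hydroxyethoxy.

With compound 3 at 87%, this read-out leaves little room upward, so any change is expected to be a modest fall rather than a rise. The expected change is a number 9 percentage points lower from compound 3 to compound 4 (within the scatter), an estimated step that may not go beyond the usual scatter. For the measured compounds named here, with no measured precedent for the added chain, the range is kept wide. In this assay the estimate for compound 4 is 78%, with an expected range of 60% to 92%.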

Compound 4, percent of the compound remaining: 45%
For compound 4 the middle estimate is 33 percentage points above the measured one; the measured number lies below the stated range.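

In this assay, among these compounds, the change on this oxygen on an aromatic ring gives the first measured step: 2-hydroxyethyl in place of hydrogen yields a number 42 percentage points lower from compound 3 to compound 4 (beyond the scatter). This position is therefore not indifferent to substitution, since hydroxy to 2-hydroxyethoxy alone moves the read-out beyond the usual scatter, and within this pair the free hydroxy compound retains more of the parent. No supporting data on the series bear on the origin of this step.

As far as these compounds go, the series offers one substituted example on this oxygen with a number, so it remains open whether the step belongs to the 2-hydroxyethyl group in particular or would accompany any group placed there. An ethyl group would test the role of the terminal hydroxy, while a 3-hydroxypropyl chain or a 2-aminoethyl group would show how far the step depends on chain length or on the terminal group; the methoxy compounds 1 and 2 differ from compound 3 in more than one place and have no result to compare.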